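The compounds below may be only part of what the source reports. "The series", "measured", "known", "first", "only" and "open" are said of these compounds alone.

Values in a functional assay on NCI-H460 cells (Homo sapiens) for cytotoxicity, read by MTT assay, with a stated time of 72 h; a higher number here means a weaker inhibitor, a lower number a stronger inhibitor:
- compound 1 `CC(C)c1[nH]cnc1/C=c1\[nH]c(=O)/c(=C/c2cccc(C(=O)c3ccc(F)cc3)c2)[nH]c1=O`: 3.2 nM
- compound 2 `O=c1[nH]/c(=C\c2ncc[nH]2)c(=O)[nH]/c1=C\c1cccc(Oc2ccc(F)cc2)c1`: > 1000 nM
- compound 3 `Cc1ccc(/C=c2\[nH]c(=O)/c(=C/c3cccc(C(=O)c4ccc(F)cc4)c3)[nH]c2=O)o1`: 5.3 nM

Compound 2 gives only a limit of the assay, > 1000 nM, and not a number. It stands at the limit of > 1000 nM in this assay, at which 1 of the 3 values shown sits.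

Compound 4 `O=c1[nH]/c(=C\c2ccc(CO)o2)c(=O)[nH]/c1=C\c1cccc(Oc2ccc(F)cc2)c1` is the next to consider. It carries 5-(hydroxymethyl)furan-2-yl in place of 1H-imidazol-2-yl on a double-bonded chain carbon bound to an aromatic carbon.

For the measured compounds named here, one measured step bears on this: a 1.7-fold higher number from compound 1 to compound 3 (0.22 log units; within the scatter). It exchanges 5-isopropyl-1H-imidazol-4-yl for 5-methylfuran-2-yl, which is a related change, but the remainder of those two molecules differs from that of compound 2. Taken alone, that step predicts no shift from the exchange itself. However, compound 3 at 5.3 nM shows that a substituted furan group can go with a low number, so a move toward a stronger inhibitor in this assay is expected, with much uncertainty.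

The expected change is an at least 3.3-fold lower number from compound 2 to compound 4 (0.52 log units; beyond the scatter).

For compound 4 the estimate is 300 nM, with an expected range of 30 nM to 2000 nM.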

Compound 4, half-maximal inhibitory concentration: 41.5 nM
Compound 4: the middle estimate sits 7.2-fold (0.86 log units) above what was measured; measured number inside the range.
By their numbers in this assay, from the lowest: compounds 1 and 3 (each within the scatter of the next); then compound 4. At a limit, above all of these: compound 2.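

In this assay, the place on a double-bonded chain carbon bound to an aromatic carbon proves able to carry a large difference, with 5-(hydroxymethyl)furan-2-yl in place of 1H-imidazol-2-yl giving an at least 24-fold lower number from compound 2 to compound 4 (1.38 log units; beyond the scatter) on an otherwise unchanged molecule. The earlier exchange of an imidazolyl for a furanyl group, a 1.7-fold higher number from compound 1 to compound 3 (0.22 log units; within the scatter), stays within the scatter, so such an exchange does not read the same in every setting, although groups and remainder both differ between the two steps. Compound 2 is a limit of the assay and not a number, so the step gives a minimum size only: the limit of > 1000 nM in this assay, at which 1 of the 4 values shown sits.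

The compounds shown do not separate the furan ring from its hydroxymethyl chain as the part that goes with the lower number. Also open, as far as these compounds go, is how an aminomethyl or a carboxylic acid in place of that hydroxymethyl would read in this assay on the core of compound 4.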